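Sulfonyl substituent variation, compound 2 to compound 3

This account rests on a few compounds, and the source may have more. Where it says the series, first, only, none or still open, it means among the compounds named here.

In a functional assay on the whole organism (trachea) with Rattus norvegicus as the target (a higher number here means a larger maximal response, a lower number a smaller maximal response), compound 1 `CC1(C)C=C(n2ccccc2=O)c2cc(S(=O)(=O)N=[N+]=[N-])ccc2O1` gives 77.2% and compound 2 `COc1ccc(NS(=O)(=O)c2ccc3c(c2)C(n2ccccc2=O)=CC(C)(C)O3)cc1` gives 84.2%. Of the two numbers compound 2 gives the larger, but the gap to compound 1 lies within the scatter: a number 7 percentage points higher from compound 1 to compound 2 (within the scatter). Compound 3 `CC1(C)C=C(n2ccccc2=O)c2cc(S(=O)(=O)N3CCOCC3)ccc2O1` differs from compound 2 in one place: morpholin-4-yl in place of (4-methoxyphenyl)amino on a sulfonyl sulfur. Within the data shown here, the single measured step also exchanged the group on the sulfonyl sulfur and stayed within the scatter, so no step beyond the scatter in this assay is expected for compound 3. The maximal response of compound 3 is estimated at 80%, within 65% to 93%. This estimate means an expected step of a number 4.2 percentage points lower from compound 2 to compound 3 (within the scatter).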

Compound 3, largest response reached (Emax), in percent of the reference or control that the assay uses: 85.1%
For compound 3 the middle estimate is 5.1 percentage points below the measured one, within the range that was stated.
By their numbers in this assay, from the lowest: compounds 1, 2 and 3 (each within the scatter of the next).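

In this assay the sulfonyl sulfur now carries a non-aromatic ring, and the picture stays flat: a number 0.9 percentage points higher from compound 2 to compound 3 (within the scatter), and a number 7.9 percentage points higher from compound 1 to compound 3 (within the scatter). Azido, (4-methoxyphenyl)amino and morpholin-4-yl therefore all lie within the scatter of each other at this place, and going from 1 hydrogen-bond donor to 0 hydrogen-bond donors on the group brings no step beyond it. Open, going by these compounds, is whether a methyl group, a carboxylic acid or a longer chain on the sulfonyl sulfur would also stay within the scatter. No supporting evidence bears on this result.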